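The compounds below may be only part of what the source reports. "The series", "measured", "known", "first", "only" and "open" are said of these compounds alone.

Measured so far:
Compound 1, `N#CN/C(=N\C1CCCC1)Nc1cc(Cl)cc(Cl)c1`: 75000 nM
Compound 2, `CC(C)CC/N=C(\NC#N)Nc1cc(C(F)(F)F)cc(C(F)(F)F)c1`: 5600 nM

Both numbers come from a functional assay (aorta) with Rattus norvegicus as the target; on this read-out higher numbers stand for weaker inhibition and lower numbers for stronger inhibition. Of the two, compound 2 stands at the lower number, and the gap to compound 1 lies beyond the usual scatter of repeated measurements, so compound 2 is the stronger inhibitor of the pair. Compound 3, `C[C@@H](/N=C(\NC#N)Nc1cc(C(F)(F)F)cc(C(F)(F)F)c1)C(C)(C)C`, has not yet been measured. It shares the core of compound 2 and differs from it in one place: 1,2,2-trimethylpropyl in place of isopentyl on a double-bonded nitrogen. Going by the values given here, the two compounds measured so far differ from each other in several places at once, so no step of this single kind has been measured, and the effect of exchanging one chain for another on the double-bonded nitrogen is unknown from these data. With only the chain changed and the rest of compound 2 kept, the expectation is a step of about a 1.1-fold lower number from compound 2 to compound 3 (0.05 log units; within the scatter) in this assay, that is, none beyond the scatter. Compound 3 is therefore expected to give 5000 nM in this assay, with a range from 1500 nM to 16000 nM.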

Compound 3, half-maximal inhibitory concentration: 20300 nM
For compound 3 the middle estimate is 4.1-fold (0.61 log units) below the measured one; the whole stated range lies below it.
By their numbers in this assay, from the lowest: compound 2; then compound 3; then compound 1.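

In this assay, putting 1,2,2-trimethylpropyl in place of isopentyl on a double-bonded nitrogen gives a 3.6-fold higher number from compound 2 to compound 3 (0.56 log units; beyond the scatter), a modest step but one beyond the scatter. Going by these compounds alone, this is the first sign that this position responds to the chain it carries, something compound 1 and compound 2 could not show, as they differ in several places at once. The data shown offer no measurement that would tie this weaker inhibition to any particular feature of the new chain, such as its 6 carbon against 5 or its defined stereocentre.

The compounds shown leave open whether the mirror-image form of the 1,2,2-trimethylpropyl chain would give a similar number, and whether an unbranched chain of the same 6 carbon would behave like compound 2 or like compound 3. They also leave open how this position would respond to quite different groups on the double-bonded nitrogen, such as a phenyl ring, an amine or a carboxylic acid.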